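The source may hold more compounds than are shown below. What is called first, only, known or untested is meant among the compounds shown, and "the series" means these compounds.

Measured so far:
- Compound 1 `O=C(Nc1ccc(Cl)c(-c2nnc3c(Cl)cccn23)c1)c1ccc(F)cc1Cl` — in a functional assay on MDA-MB-231 cells (Homo sapiens) for antiproliferative activity, read by MTT assay, with stated times of 72 h and 4 h (a higher number here means a weaker inhibitor, a lower number a stronger inhibitor), compound 1 gives 75000 nM.
- Compound 2 `O=C(Nc1ccc(Cl)c(-c2nnc3c(Cl)cccn23)c1)c1ccc(Cl)cc1Cl` — in this assay compound 2 gives > 100000 nM, which is a limit of the assay and not a number.

Within the data shown here, compound 2 therefore stands only at a limit; the one measured step, an at least 1.3-fold higher number from compound 1 to compound 2 (0.12 log units; that floor lies within the scatter), rests on that limit of > 100000 nM in this assay, at which 1 of the 2 values shown sits, and says little more than that both compounds are weak here.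

The next compound, compound 3 `O=C(Nc1ccc(Cl)c(-c2nnc3c(Cl)cccn23)c1)c1ccon1`, differs from compound 2 by 1,2-oxazol-3-yl in place of 2,4-dichlorophenyl on a carbonyl carbon. Among the measured compounds shown here, no measured step touches this position beyond the halogen swap, so the change is untested; the only precedent is that both amides carrying a substituted phenyl on the carbonyl are weak.

Compound 3 is expected to give 100000 nM, within 30000 nM to 300000 nM. The implied step, a number no higher from compound 2 to compound 3 (the limit leaves the size open), is an estimate only, with a real chance that only a limit is again reported.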

Compound 3, half-maximal inhibitory concentration: > 100000 nM
Compound 3 gave a limit, no number; the forecaster's own chance of this, stated with the estimate: 55%; the middle value lies on the limit itself.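

In this assay compound 3 gives > 100000 nM as a limit of the assay and not a number. Among these compounds, with 1,2-oxazol-3-yl on the carbonyl carbon, the one comparison that can be read is an at least 1.3-fold higher number from compound 1 to compound 3 (0.12 log units; that floor lies within the scatter) and this extends the weak readings beyond amides carrying a substituted phenyl to one carrying a five-membered aromatic ring with hetero atoms. The step between compound 2 and compound 3 cannot be read, and the readings at this position remain capped: the limit of > 100000 nM in this assay, at which 2 of the 3 values shown sit.

On these data alone, whether any group on this carbonyl carbon can bring a value well within the range of the assay stays open, for example a phenyl ring carrying a carboxylic acid or a piperidine amide. As far as these compounds go, whether the shared core itself limits the activity also stays open.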